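A 1-Benzofuran-2-yl Swap at the Assay Limit

The source may report more compounds than this note shows. Statements on the series, on what has been measured and on what is new or still open speak of the compounds shown alone.

Of the compounds shown here, three sharing one core have been tested in a toxicity assay on Huh-7 cells (Homo sapiens) for cytotoxicity, with a stated time of 3 days; on this read-out lower numbers stand for higher toxicity in this test and higher numbers for lower toxicity in this test. Compound 1 `COc1ccc(-c2cn([C@@H]3O[C@H](CO)[C@@H](O)[C@@]3(C)O)c3ncnc(N)c23)cc1` carries 4-methoxyphenyl, and its result is a limit, > 44000 nM. Compound 2 `C[C@@]1(O)[C@H](O)[C@@H](CO)O[C@H]1n1cc(-c2cccc3ccccc23)c2c(N)ncnc21` carries naphthalen-1-yl, and its result is also a limit, > 44000 nM. Compound 3 `C[C@@]1(O)[C@H](O)[C@@H](CO)O[C@H]1n1cc(-c2ccsc2)c2c(N)ncnc21` carries thiophen-3-yl, and its result is again a limit, > 44000 nM. Compound 3 therefore stands with the other two, as the limit of > 44000 nM in this assay, at which 3 of the 3 values shown sit, shows.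

Compound 4 `C[C@@]1(O)[C@H](O)[C@@H](CO)O[C@H]1n1cc(-c2cc3ccccc3o2)c2c(N)ncnc21` has 1-benzofuran-2-yl in place of thiophen-3-yl on the same aromatic carbon: 1-benzofuran-2-yl in place of thiophen-3-yl on an aromatic carbon.

Three measured steps exchange a group at this same place: a step that the two limits leave unreadable from compound 1 to compound 2, a step that the two limits leave unreadable from compound 1 to compound 3 and a step that the two limits leave unreadable from compound 2 to compound 3. None of them has a readable size, so they offer no number to carry over. Going by the values given here, they do show that all three groups tested here left the result at the same limit, and no compound goes against this. On that basis, no change beyond the usual scatter is expected, and a further limit is the likeliest result. The expected step is a number no higher from compound 3 to compound 4 (the limit leaves the size open). For compound 4, the estimated half-maximal cytotoxic concentration is 44000 nM, with an expected range from 20000 nM to 100000 nM.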

Compound 4, half-maximal cytotoxic concentration: 29400 nM
Compound 4: the middle estimate sits 1.5-fold (0.18 log units) above what was measured; the range from low to high includes it.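

In this assay, 1-benzofuran-2-yl at this place gives the only result among the four compounds that is a number rather than a limit, and the steps to it are an at least 1.4-fold lower number from compound 3 to compound 4 (0.17 log units; that floor lies within the scatter), an at least 1.4-fold lower number from compound 2 to compound 4 (0.17 log units; that floor lies within the scatter) and an at least 1.4-fold lower number from compound 1 to compound 4 (0.17 log units; that floor lies within the scatter). Each of these sizes is only a floor, and the comparison still rests on the limit reached by the other compounds: the limit of > 44000 nM in this assay, at which 3 of the 4 values shown sit. Two fused aromatic rings at this place do not by themselves yield a number, since compound 2, with naphthalen-1-yl, has a result that is a limit, > 44000 nM.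

All the groups shown at this place are aromatic rings, so it remains open whether an amine, a carboxylic acid or a longer chain would leave the result at the limit or give a readable number. From the compounds shown here alone, the true values of compound 1, compound 2 and compound 3 also remain unknown, which leaves open whether the change to 1-benzofuran-2-yl has any effect beyond the usual scatter of this test.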